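Rearranging the iodo and methoxy groups on the anilino ring

The source may hold more compounds than are shown below. What is called first, only, known or untested is meant among the compounds shown, and "the series" means these compounds.

Measured compounds:
compound 1, `COc1cc(NC(=O)Nc2cc(Nc3cc(Br)ccc3OC)ncn2)cc(OC)c1`, 42.7%
compound 2, `COc1cc(NC(=O)Nc2cc(Nc3cc(C)cc(F)c3)ncn2)cc(OC)c1`, 35.3%
compound 3, `COc1cc(NC(=O)Nc2cc(Nc3ccc(OC)c(I)c3)ncn2)cc(OC)c1`, 40.1%

In a functional assay on NCI-H226 cells (Homo sapiens) for inhibition, read by MTT assay, with a stated time of 48 h, tested at 10 uM (on this read-out lower numbers stand for less inhibition and higher numbers for more inhibition at the one concentration tested (going by the name of the read-out)), compound 3 gives 40.1%, the second highest of the three numbers. Its nearest neighbour is compound 1, which gives 42.7%; the step of a number 2.6 percentage points lower from compound 1 to compound 3 (within the scatter). The furthest is compound 2, which gives 35.3%; the step of a number 4.8 percentage points higher from compound 2 to compound 3 (within the scatter). Compound 1 and compound 2 are also close: a number 7.4 percentage points lower from compound 1 to compound 2 (within the scatter). None of the three measured steps leaves the scatter.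

Compound 4, `COc1cc(NC(=O)Nc2cc(Nc3cc(I)ccc3OC)ncn2)cc(OC)c1`, has not yet been measured. It differs from compound 3 by 5-iodo-2-methoxyphenyl in place of 3-iodo-4-methoxyphenyl on a nitrogen on an aromatic ring. Among the measured compounds shown here, the change that bears most directly on it is the one from compound 1 to compound 3, where a bromine and a 2-methoxy pattern were replaced by an iodine and a 4-methoxy pattern, and the number hardly moved; the two other steps, which also exchange the whole aryl group on that nitrogen, were equally small. Compound 4 carries the same ring pattern as compound 1 with iodine in place of bromine, so no step beyond the scatter is expected in this assay.

The step of a number 1.9 percentage points higher from compound 3 to compound 4 (within the scatter) is therefore the expectation. Compound 4 is estimated to give 42%, within a range from 31% to 53%.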

Compound 4, a percentage reported as inhibition, at one concentration (the size of the read-out at that concentration, not a potency): 56.7%
Beside the measured number, compound 4's estimate is 14.7 percentage points below it; measured number outside the range, above it.
By their numbers in this assay, from the lowest: compounds 2, 3 and 1 (each within the scatter of the next); then compound 4.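

Swapping 3-iodo-4-methoxyphenyl for 5-iodo-2-methoxyphenyl on a nitrogen on an aromatic ring, with the same atoms joined differently, gives a number 16.6 percentage points higher from compound 3 to compound 4 (beyond the scatter) in this assay, so at this position the arrangement of the iodo and methoxy groups counts, not just their presence. The halogen counts too: iodo in place of bromo on an aromatic carbon gives a number 14 percentage points higher from compound 1 to compound 4 (beyond the scatter), even though the exchanges of the whole aryl group among compound 1, compound 2 and compound 3 all stayed within the scatter. The 5-iodo-2-methoxyphenyl group also stands clear of 3-fluoro-5-methylphenyl, with a number 21.4 percentage points higher from compound 2 to compound 4 (beyond the scatter) as the largest of the new steps, and compound 1 shows that the shared ring pattern does not produce the rise on its own. Nothing at hand explains why the number rises.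

As far as these compounds go, whether a chloro group in place of the iodo, or an ethoxy or dimethylamino group in place of the methoxy, would move the number further remains open. With a single concentration in a single cell line, the result also leaves open how potent compound 4 is and whether the step holds elsewhere.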